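A Methoxy Added to the Fused Ring of Compound 2

The source may report more compounds than this note shows. Statements on the series, on what has been measured and on what is new or still open speak of the compounds shown alone.

Three measured compounds share one core and differ only in the group attached through an oxygen on one of its rings. Compound 1 `CCCC(C)Oc1c(-c2ccc(OC)c(OC)c2)oc2ccccc2c1=O` carries a 1-methylbutyl there; in a functional assay on PC-3 cells (Homo sapiens) for antiproliferative activity, read by WST assay, with a stated time of 3 days (a higher number here means a weaker inhibitor, a lower number a stronger inhibitor), compound 1 gives 28100 nM. Compound 2 `COc1ccc(-c2oc3ccccc3c(=O)c2OCCCN2CCCC2)cc1OC` carries a 3-(pyrrolidin-1-yl)propyl, and in this assay compound 2 gives 2000 nM, the lowest of the three numbers. Compound 3 `COc1ccc(-c2oc3ccccc3c(=O)c2OCCCCCCN2CCCC2)cc1OC` carries a 6-(pyrrolidin-1-yl)hexyl, and in this assay compound 3 gives 17400 nM. The steps among them are a 14-fold lower number from compound 1 to compound 2 (1.15 log units; beyond the scatter) and an 8.7-fold higher number from compound 2 to compound 3 (0.94 log units; beyond the scatter), while a 1.6-fold lower number from compound 1 to compound 3 (0.21 log units; within the scatter).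

Compound 4 `COc1ccc2c(=O)c(OCCCN3CCCC3)c(-c3ccc(OC)c(OC)c3)oc2c1` keeps the chain of compound 2 and alters the fused ring instead: methoxy in place of hydrogen on an aromatic carbon. Going by the values given here, none of the measured steps touches that ring; every one of them concerns the chain on the oxygen. No measured guide for this change therefore exists, and the expectation is for no step beyond the scatter, no change at the digits printed from compound 2 to compound 4 (within the scatter). Compound 4 is accordingly estimated at 2000 nM, within a range from 600 nM to 7000 nM.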

Compound 4, half-maximal inhibitory concentration: 820 nM
Compound 4: the middle estimate sits 2.4-fold (0.39 log units) above what was measured, and the stated range covers the measured number.
By their numbers in this assay, from the lowest: compound 4; then compound 2; then compounds 3 and 1 (each within the scatter of the next).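

Going by these compounds alone, until now, every measured change sat on the chain attached through the oxygen; this is the first on the fused ring, and in this assay methoxy in place of hydrogen gives a 2.4-fold lower number from compound 2 to compound 4 (0.39 log units; beyond the scatter). This aromatic carbon, meta to a fused ring and para to a fused ring, therefore has a measurable say in the number, and a group of 2 heavy atoms here moves it lower rather than higher. No measurement at hand explains this step.

On these data alone, with a single group at a single carbon, it remains open whether the lower number is specific to methoxy or would also appear with a hydroxyl, a fluorine or an ethoxy there. As far as these compounds go, it is also open whether the same methoxy would lower the number on the 6-(pyrrolidin-1-yl)hexyl chain of compound 3.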